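Methyl on the outer ring: a repeated small change

The source may report more compounds than this note shows. Statements on the series, on what has been measured and on what is new or still open speak of the compounds shown alone.

Measured compounds:
compound 1, `COc1cc(C(=O)NNC(=S)Nc2csc(-c3ccccc3)c2)cc(OC)c1OC`, 55000 nM
compound 2, `COc1cc(C(=O)NNC(=S)Nc2csc(-c3ccc(C)cc3)c2)cc(OC)c1OC`, 42000 nM
compound 3, `O=C(NNC(=S)Nc1csc(-c2ccccc2)c1)c1ccc(O)cc1`, 71000 nM

Of the compounds shown here, three have been tested in a functional assay on SK-MEL-28 cells (Homo sapiens) for inhibition, read by colorimetric assay and MTT assay, with a stated time of 72 h; a lower number here means a stronger inhibitor, a higher number a weaker inhibitor. Compound 1 gives 55000 nM, compound 2 gives 42000 nM and compound 3 gives 71000 nM. All three numbers lie close together, and none of the gaps between them is larger than the usual scatter of repeated runs, so no one of them can be called stronger or weaker than another.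

Compounds 1 and 2 differ by one change: methyl in place of hydrogen on an aromatic carbon. That change gave a 1.3-fold lower number from compound 1 to compound 2 (0.12 log units; within the scatter), a shift too small to count as a real difference.

Compound 3 has a different core from compound 1; how the two cores differ is not broken down here. Compound 4, `Cc1ccc(-c2cc(NC(=S)NNC(=O)c3ccc(O)cc3)cs2)cc1`, has not yet been measured. It stands to compound 3 as compound 2 stands to compound 1: methyl in place of hydrogen on an aromatic carbon. The place of the new group is described in the same words in both cases, so this is the same change made on a second core.

Because the earlier step of a 1.3-fold lower number from compound 1 to compound 2 (0.12 log units; within the scatter) stayed within the scatter, the step from compound 3 to compound 4 is expected to be small as well, about a 1.2-fold lower number from compound 3 to compound 4 (0.09 log units; within the scatter). Compound 4 is therefore estimated to give 58000 nM in this assay, with a likely range from 30000 nM to 120000 nM.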

Compound 4, half-maximal inhibitory concentration: 46000 nM
Compound 4: the middle estimate sits 1.3-fold (0.10 log units) above what was measured; low and high end bracket the measured number.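

In this assay, the change from phenyl to 4-methylphenyl on the second core gave a 1.5-fold lower number from compound 3 to compound 4 (0.19 log units; within the scatter), so here too the added methyl leaves the number inside the usual scatter of repeated measurements. Set beside the earlier step, the change looks the same on both cores, and the two steps cannot be told apart: the same change on two cores in this assay, a 1.3-fold lower number (0.12 log units; within the scatter) from compound 1 to compound 2 and a 1.5-fold lower number (0.19 log units; within the scatter) from compound 3 to compound 4, 1.2-fold (0.07 log units) apart, within the scatter of two such steps. This shows that, across these two pairs of compounds, the methyl made no readable difference on either core; it does not show that the methyl has any real effect, and two steps this small are only a weak test of whether a clear effect would carry from one core to the other.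

The compounds shown carry only hydrogen or methyl at this place on the outer ring, so it remains open whether a different group there, such as a chlorine, a methoxy, an amine or a carboxylic acid, would move the number beyond the scatter. As far as these compounds go, it also remains open whether such a step would have the same size on both cores.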